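Adding a Nitro Group to Compound 2

A few compounds are considered here, and "the series" means these few. Any claim that something is new, unique, unknown or untested is made for them only; others in the source may bear on it.

Compound 1 `CCn1cc(-c2nc3ccccc3[nH]2)c(=O)c2cc(F)c(N3CCNCC3)cc21` gives 27400 nM in a functional assay on Bel-7402 cells (Homo sapiens) for cytotoxicity, read by MTT assay, with a stated time of 48 h; a higher number here means a weaker inhibitor, a lower number a stronger inhibitor. Compound 2 `CCn1cc(-c2nc3ccccc3s2)c(=O)c2cc(F)c(N3CCNCC3)cc21` gives 24300 nM, and the step of a 1.1-fold lower number from compound 1 to compound 2 (0.05 log units; within the scatter) shows the two numbers lie within the usual scatter of each other, so neither stands apart. Compound 3 `CCn1cc(-c2nc3ccc([N+](=O)[O-])cc3s2)c(=O)c2cc(F)c(N3CCNCC3)cc21` differs from compound 2 by nitro in place of hydrogen on an aromatic carbon. Among the compounds with values here, no measured step bears on a nitro entering at this place; the only known step concerns a different change and stayed within the scatter, so the expected step is a 1.0-fold lower number from compound 2 to compound 3 (0.01 log units; within the scatter), with no direction claimed. Compound 3 is therefore expected to give 24000 nM, within a range from 8000 nM to 70000 nM.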

Compound 3, half-maximal inhibitory concentration: 1800 nM
Compound 3: middle estimate off by 13-fold (1.12 log units), on the high side; measured number below the stated range.
By their numbers in this assay, from the lowest: compound 3; then compounds 2 and 1 (each within the scatter of the next).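

In this assay, nitro in place of hydrogen on this aromatic carbon gives a 14-fold lower number from compound 2 to compound 3 (1.13 log units; beyond the scatter) while the earlier exchange of one fused group for the other stayed within the scatter. This place on the six-membered aromatic ring of carbon only can therefore shift the number far, which compound 1 and compound 2 alone could not show. Nothing available here explains the size of this step. From the compounds shown here alone, whether the shift is specific to nitro remains open, since an amine or a nitrile at this place could behave alike or differently. Also open, going by these compounds, is whether nitro would produce a similar step on the 1H-benzimidazol-2-yl group of compound 1.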